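The source may hold more compounds than are shown below. What is called first, only, known or untested is meant among the compounds shown, and "the series" means these compounds.

Measured compounds and their values:

Compound 1, `CC(O)Cn1c([N+](=O)[O-])cnc1/C=C/c1cccc(F)c1`, gives 1030 nM in an ADME assay on cells (Macrophage, Homo sapiens) for cytotoxicity, read by MTT assay, with a stated time of 24 h; on this read-out higher numbers stand for lower toxicity in this test and lower numbers for higher toxicity in this test.
Compound 2, `CC(O)Cn1c([N+](=O)[O-])cnc1/C=C/c1cccc(Br)c1`, gives 620 nM in this assay.
Compound 3, `CC(O)Cn1c([N+](=O)[O-])cnc1/C=C/c1ccccc1Cl`, gives 480 nM in this assay.

Compound 3 is set apart from compound 1 alone: a 2.1-fold lower number from compound 1 to compound 3 (0.33 log units; beyond the scatter). Against compound 2 it cannot be told apart, since a 1.3-fold lower number from compound 2 to compound 3 (0.11 log units; within the scatter). Compound 4, `CC(O)Cn1c([N+](=O)[O-])cnc1/C=C/c1ccccc1Br`, differs from compound 3 in one place: bromo in place of chloro on an aromatic carbon. Of the measured steps, only the exchange of halogens on the aromatic ring bears on this change, and there it ran from fluoro to bromo rather than from chloro to bromo: a 1.7-fold lower number from compound 1 to compound 2 (0.22 log units; within the scatter). Among the measured compounds shown here, no step from chloro to bromo has been measured, so the swap in compound 4 is judged from that single halogen exchange, which stayed within the scatter. Compound 4 is therefore expected to give a number close to that of compound 3 in this assay, perhaps a little lower, with the expected step being a 1.1-fold lower number from compound 3 to compound 4 (0.03 log units; within the scatter). The estimate for compound 4 is 450 nM, with a range from 220 nM to 900 nM.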

Compound 4, half-maximal cytotoxic concentration: 490 nM
For compound 4 the middle estimate is 1.1-fold (0.04 log units) below the measured one, within the range that was stated.
By their numbers in this assay, from the lowest: compounds 3, 4, 2 and 1 (each within the scatter of the next, the first and the last beyond it).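

In this assay, the direct exchange of chloro for bromo on this aromatic carbon, ortho to a large group, cannot be read as a change, with a 1.0-fold higher number from compound 3 to compound 4 (0.01 log units; within the scatter). The 2-bromophenyl group also cannot be told apart from the 3-bromophenyl group, with a 1.3-fold lower number from compound 2 to compound 4 (0.10 log units; within the scatter), but it does separate from the 3-fluorophenyl group, with a 2.1-fold lower number from compound 1 to compound 4 (0.32 log units; beyond the scatter), a step that changes both the halogen and its place on the ring. No evidence is available that accounts for these numbers.

The compounds shown leave open whether the gap to the 3-fluorophenyl group follows the halogen or its place on the ring, a question that a 2-fluorophenyl or 3-chlorophenyl group would help to settle. They also leave open how a group other than a halogen on this aromatic carbon, such as a methoxy group, an amine or a carboxylic acid, would read in this assay.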